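A few compounds are considered here, and "the series" means these few. Any claim that something is new, unique, unknown or untested is made for them only; others in the source may bear on it.

Of the compounds shown here, three have so far been measured in an ADME assay on L6 cells (Rattus norvegicus) for cytotoxicity, read by resazurin assay, with a stated time of 70 h; on this read-out lower numbers stand for stronger inhibition and higher numbers for weaker inhibition. Compound 1 `c1ccc(OCCCCCOc2cccc(-c3cc4cc(C5=NCCN5)ccc4o3)c2)cc1` and compound 2 `c1ccc(OCCCCCCOc2cccc(-c3cc4cc(C5=NCCN5)ccc4o3)c2)cc1` share one core, while compound 3 `N=C(N)c1ccc2oc(-c3ccc(OCCCCCOc4ccccc4)cc3)cc2c1` and the still unmeasured compound 4 `N=C(N)c1ccc2oc(-c3ccc(OCCCCCCOc4ccccc4)cc3)cc2c1` share another; the difference between the two cores is not broken down here. In this assay compound 1 gives 2600 nM and compound 2 gives 2500 nM, two values that lie within the usual scatter of each other. The structural change between them is phenoxymethyl in place of phenoxy on a saturated chain carbon, five bonds along the chain from an oxygen on an aromatic ring, and it produced a 1.0-fold lower number from compound 1 to compound 2 (0.02 log units; within the scatter). Compound 3 gives 4200 nM in this assay, a number that also lies within the scatter of the values of compound 1 and compound 2. Compound 4 carries the same change as compound 2, now on the core of compound 3: phenoxymethyl in place of phenoxy on a saturated chain carbon, five bonds along the chain from an oxygen on an aromatic ring. The change sits at the same place in both pairs, so it is the same change. The step expected from compound 3 to compound 4 in this assay is estimated at no change at the digits printed from compound 3 to compound 4 (within the scatter), resting on the earlier step of a 1.0-fold lower number from compound 1 to compound 2 (0.02 log units; within the scatter). Compound 4 is therefore expected to give about 4200 nM, with a likely range from 2400 nM to 7500 nM.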

Compound 4, half-maximal inhibitory concentration: 3300 nM
For compound 4 the middle estimate is 1.3-fold (0.10 log units) above the measured one; the measured number falls inside the stated range.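

In this assay the swap of phenoxy for phenoxymethyl on the core of compound 3 gives a 1.3-fold lower number from compound 3 to compound 4 (0.10 log units; within the scatter), a shift that cannot be told apart from the noise of repeated measurements. Among these compounds, each core supplies only one pair, so this does not show that the two cores respond identically, or that the change would leave the number unmoved on any other core. Within these two cores, the change carries over with no detectable difference: the same change on two cores in this assay, a 1.0-fold lower number (0.02 log units; within the scatter) from compound 1 to compound 2 and a 1.3-fold lower number (0.10 log units; within the scatter) from compound 3 to compound 4, 1.2-fold (0.09 log units) apart, within the scatter of two such steps

The compounds shown stop at phenoxymethyl, so it remains open whether a longer chain, such as 2-phenoxyethyl or 3-phenoxypropyl, would produce a step beyond the scatter on either core. From the compounds shown here alone, it is also open whether an amine or a carboxylic acid in place of the phenoxy group would behave alike on both cores, which would be a stricter test of carrying a change from one core to the other.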